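Tetrazole to sulfamoyl on the biaryl of a benzopyran

This account rests on a few compounds, and the source may have more. Where it says the series, first, only, none or still open, it means among the compounds named here.

For the measured compounds named here, compound 1 `O[C@H]1c2ccc(-c3cc(F)ccc3-c3nn[nH]n3)cc2OC[C@@H]1Cc1ccccc1` is examined in an assay on isolated protein for binding affinity to leukotriene B4 receptor (Homo sapiens) (on this read-out lower numbers stand for stronger inhibition and higher numbers for weaker inhibition), where compound 1 gives 20 nM, the only number reported for it alongside a further entry that carries no single figure. Compound 2 `O=S(=O)(Nc1ccc(F)cc1-c1ccc2c(c1)OC[C@H](Cc1ccccc1)[C@H]2O)C(F)(F)F` carries a trifluoromethylsulfonylamino group in place of the tetrazole and in this assay compound 2 gives 50 nM; 3.8 nM (2 entries); the spread between these entries, (the several entries of compound 2 in this assay, 50 nM; 3.8 nM (2 entries)), shows how far repeated readings of one compound can lie apart. Compound 3 `NS(=O)(=O)c1ccc(F)cc1-c1ccc2c(c1)OC[C@H](Cc1ccccc1)[C@H]2O` differs from compound 1 by sulfamoyl in place of 2H-tetrazol-5-yl on an aromatic carbon. Going by the values given here, no measured pair shows the effect of this exchange. Among the compounds with values here, since no step in the data addresses it, the direction is uncertain, yet compound 3 is expected to come out somewhat weaker than compound 1, with the step from compound 1 to compound 3 estimated at a 3.0-fold higher number from compound 1 to compound 3 (0.48 log units; beyond the scatter), beyond the usual scatter. Compound 3 is estimated at 60 nM, within a range from 15 nM to 300 nM.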

Compound 3, half-maximal inhibitory concentration: 37 nM
Compound 3: middle estimate off by 1.6-fold (0.21 log units), on the high side, and the stated range covers the measured number.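

The exchange of 2H-tetrazol-5-yl for sulfamoyl, ortho to a large group and para to a fluoro group, gives in this assay a 1.9-fold higher number from compound 1 to compound 3 (0.27 log units; within the scatter) and so leaves the reading unchanged within the usual scatter. The earlier compounds shown here could not show this, and it means that in this pair the five-membered aromatic ring is not required at this position for a reading of this order. This comparison rests on few readings and should be held loosely, because repeated readings of one compound in this assay can lie far apart: the several entries of compound 2 in this assay, 50 nM; 3.8 nM (2 entries)

The compounds shown leave open whether a carboxylic acid or a methylsulfonylamino group at this position would read alike. They also leave open whether the sulfamoyl result would hold with a chloro group in place of the fluoro group.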